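Bis-aryl ether linker series: acid to amide swap

The source may hold more compounds than are shown below. What is called first, only, known or untested is meant among the compounds shown, and "the series" means these compounds.

Measured so far:
compound 1, `Cc1ccc(OCCCCOc2ccc(C(=O)CC(C)(C)C)c(O)c2C)cc1C(=O)O`: 309 nM
compound 2, `Cc1ccc(C(=O)O)cc1OCCCCOc1ccc(C(=O)CC(C)(C)C)c(O)c1C`: 892 nM

In an assay for positive allosteric modulation of metabotropic glutamate receptor 3 (Rattus norvegicus) (a higher number here means that more compound is needed for the effect, a lower number that less compound is needed), compound 1 gives 309 nM and compound 2 gives 892 nM. Within the data shown here, compound 2 thus stands at the higher of the two numbers, with compound 1 as its only neighbour at a lower value; the step of a 2.9-fold higher number from compound 1 to compound 2 (0.46 log units; beyond the scatter) shows that moving the carboxy and methyl groups around the terminal ring alone shifts the number beyond the scatter.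

Compound 3, `Cc1c(OCCCCOc2ccc(F)c(C(N)=O)c2)ccc(C(=O)CC(C)(C)C)c1O`, is to be measured in this assay. The change from compound 2 is 3-carbamoyl-4-fluorophenyl in place of 5-carboxy-2-methylphenyl on an oxygen on a saturated carbon. Among the measured compounds shown here, no measured step covers this exchange: the only step in hand, a 2.9-fold higher number from compound 1 to compound 2 (0.46 log units; beyond the scatter), concerns a rearrangement of the same two groups and keeps the acid, whereas here the acid and methyl both leave. That step only indicates that the terminal ring is sensitive to its substitution pattern, and that a modest movement in either direction is plausible. In the absence of a closer precedent the expectation is that compound 3 remains near compound 2, with the step of a 1.3-fold lower number from compound 2 to compound 3 (0.11 log units; within the scatter) estimated as small, so compound 3 is expected to give about 700 nM, within 200 nM to 2500 nM.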

Compound 3, half-maximal effective concentration: "not active" (no number reported)
The entry for compound 3 holds no number, and the estimate cannot be compared.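

In this assay, among these compounds, compound 3 is reported as "not active" with no number, so no step from compound 2 to compound 3 can be read. No measurement in hand bears on this result. The compounds shown leave open which part of the exchange of 5-carboxy-2-methylphenyl for 3-carbamoyl-4-fluorophenyl goes with it.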